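Nitrophenyl Position Changed on a Methyl-Bearing Analogue

This account rests on a few compounds, and the source may have more. Where it says the series, first, only, none or still open, it means among the compounds named here.

Three compounds were measured in a functional assay on HL-60 cells (Homo sapiens) for inhibition, read by CCK-8 assay, with a stated time of 48 h, tested at 20 uM; on this read-out higher numbers stand for more inhibition of growth at the one concentration tested and lower numbers for less inhibition of growth. Compound 1 `N#C/C(=C\c1ccccc1OS(=O)(=O)c1ccc([N+](=O)[O-])cc1)C(=O)Nc1nnc(Cc2ccccc2)s1` gives 20%, compound 2 `N#C/C(=C\c1ccccc1OS(=O)(=O)c1ccccc1[N+](=O)[O-])C(=O)Nc1nnc(Cc2ccccc2)s1` gives 12%, and compound 3 `Cc1ccc(Cc2nnc(NC(=O)/C(C#N)=C/c3ccccc3OS(=O)(=O)c3ccc([N+](=O)[O-])cc3)s2)cc1` gives 17%. Two steps connect them. The first is 2-nitrophenyl in place of 4-nitrophenyl on a sulfonyl sulfur, which made a number 8 percentage points lower from compound 1 to compound 2 (within the scatter). The second is methyl in place of hydrogen on an aromatic carbon, which made a number 3 percentage points lower from compound 1 to compound 3 (within the scatter).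

Compound 4 `Cc1ccc(Cc2nnc(NC(=O)/C(C#N)=C/c3ccccc3OS(=O)(=O)c3ccccc3[N+](=O)[O-])s2)cc1` has not been measured. It differs from compound 3 by 2-nitrophenyl in place of 4-nitrophenyl on a sulfonyl sulfur. This is the same change as that from compound 1 to compound 2, made at a place described in the same words; the cores of the two pairs differ by the methyl in place of hydrogen that separates compound 3 from compound 1.

Since the change has been seen once, the step is expected to be of similar size: a number 7 percentage points lower from compound 3 to compound 4 (within the scatter) is estimated, set beside the earlier a number 8 percentage points lower from compound 1 to compound 2 (within the scatter). Resting on compound 3 at 17%, compound 4 is expected to give about 10% in this assay, with a range from 0% to 22%.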

Compound 4, percent growth inhibition at one concentration: 33%
Compound 4: the middle estimate sits 23 percentage points below what was measured; the measured number lies above the stated range.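

In this assay, 2-nitrophenyl in place of 4-nitrophenyl on a sulfonyl sulfur made a number 16 percentage points higher from compound 3 to compound 4 (beyond the scatter), so the step seen on the core of compound 1 did not carry over to the methyl-bearing core: the same change on two cores in this assay, a number 8 percentage points lower (within the scatter) from compound 1 to compound 2 and a number 16 percentage points higher (beyond the scatter) from compound 3 to compound 4, 24 percentage points apart, beyond the scatter of two such steps. Methyl in place of hydrogen on an aromatic carbon made a number 21 percentage points higher from compound 2 to compound 4 (beyond the scatter), so its step also changed with the group on the sulfonyl sulfur: the same change on two cores in this assay, a number 3 percentage points lower (within the scatter) from compound 1 to compound 3 and a number 21 percentage points higher (beyond the scatter) from compound 2 to compound 4, 24 percentage points apart, beyond the scatter of two such steps. This shows that in these four compounds the two changes do not act independently, so the step from one core cannot be transferred to the other, but it does not show why, or how either change would behave on any further core.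

The compounds shown leave open whether this dependence extends to other groups, such as an amine or a carboxylic acid in place of the nitro group. They also leave open what a longer chain in place of the methyl would do with each nitrophenyl.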